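Swapping iodo for methyl on a measured core

The source may hold more compounds than are shown below. What is called first, only, known or untested is meant among the compounds shown, and "the series" means these compounds.

Of the compounds shown here, three have so far been measured in a functional assay on L1210 cells (Mus musculus) for inhibition; a higher number here means a weaker inhibitor, a lower number a stronger inhibitor. Compound 1 `OC[C@H]1O[C@@H](n2cc(Br)c3c(NO)ncnc32)[C@H](O)[C@@H]1O` gives 25000 nM in this assay. Compound 2 `Nc1ncnc2c1c(I)cn2COC(CO)CO` gives 2800 nM in this assay. Compound 3 `OCC(CO)OCn1cc(Cl)c2c(NO)ncnc21` gives 75000 nM in this assay. Compound 2 stands lowest of the three numbers, and its distances to compound 1 and to compound 3 both lie beyond the usual scatter, so among these three it is the strongest inhibitor.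

Compound 4 `Cc1cn(COC(CO)CO)c2ncnc(N)c12` has not yet been measured. It differs from compound 2 in one place: methyl in place of iodo on an aromatic carbon. No two of the measured compounds differ from each other in a single place, so the size of such a step cannot be read from the measured numbers. The author expects the number to rise by a step of a 5.4-fold higher number from compound 2 to compound 4 (0.73 log units; beyond the scatter), beyond the scatter, toward a weaker inhibitor. Compound 4 is therefore estimated at 15000 nM, with a range from 3000 nM to 70000 nM.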

Compound 4, half-maximal inhibitory concentration: > 100000 nM
Compound 4 gave a limit, no number (the forecaster's own chance of this, stated with the estimate: 10%); at least 6.6-fold (0.82 log units) between middle value and limit.
By their numbers in this assay, from the lowest: compound 2; then compound 1; then compound 3. At a limit, above all of these: compound 4.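

The change from iodo to methyl is the only single-place comparison shown, and it gives a first reading of how much this aromatic carbon of the five-membered ring matters: in this assay it produces an at least 35-fold higher number from compound 2 to compound 4 (1.55 log units; beyond the scatter). Iodo and methyl each count one heavy atom and no hydrogen-bond donors or acceptors, so these counts do not separate the two groups, yet the read-out does. Compound 4 stands at > 100000 nM, which is a limit of the assay and not a number, so the step gives only a bound on the real difference: the limit of > 100000 nM in this assay, at which 1 of the 4 values shown sits.

Going by these compounds, what an ethyl group or a nitrile at this carbon would give on the shared core remains open. Bromo and chloro appear only on compounds that differ in more than one place, so their steps cannot be read.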